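A Pyridine-N-oxide Piperidine Amide Series: Cyclohexyl to Aryl

This account rests on a few compounds, and the source may have more. Where it says the series, first, only, none or still open, it means among the compounds named here.

Measured so far in a functional assay on HEK293 cells for agonist activity at D(4) dopamine receptor (Homo sapiens), read by FLIPR; on this read-out higher numbers stand for an effect only at larger amounts of compound and lower numbers for an effect already at smaller amounts:
Compound 1 `Cc1ccc([N+](=O)[O-])cc1NC(=O)CN1CCC(c2cccc[n+]2[O-])CC1` gives 134 nM.
Compound 2 `N#Cc1cccc(C(=O)NCN2CCC(c3cccc[n+]3[O-])CC2)c1` gives 840 nM.
Compound 3 `O=C(CN1CCC(c2cccc[n+]2[O-])CC1)NC1CCCCC1` gives 294 nM.

Compound 3 stands second highest of the three numbers. Its nearest neighbour is compound 1, which gives a number lower by more than the usual scatter, while compound 2 lies furthest away with a number higher by more than the scatter. All three share the same core, a piperidine bearing the pyridine-N-oxide, joined through an acetamide to a variable substituent on the amide nitrogen.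

Compound 4 `Cc1cc(Br)ccc1NC(=O)CN1CCC(c2cccc[n+]2[O-])CC1` has not yet been measured. It differs from compound 3 in one place: 4-bromo-2-methylphenyl in place of cyclohexyl on an amide-type nitrogen

Among the compounds with values here, no measured pair isolates exactly this exchange. The nearest guidance is that compound 1 gives 134 nM while compound 3 gives 294 nM, a difference that lies beyond the scatter. On this basis the step of a 2.0-fold lower number from compound 3 to compound 4 (0.29 log units; within the scatter) is expected to be modest and towards a lower number, though it may also fall within the scatter. Compound 4 is therefore estimated at 150 nM, with a plausible range from 50 nM to 450 nM.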

Compound 4, half-maximal effective concentration: 66 nM
For compound 4 the middle estimate is 2.3-fold (0.36 log units) above the measured one; measured number inside the range.
By their numbers in this assay, from the lowest: compound 4; then compound 1; then compound 3; then compound 2.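

In this assay, within the data shown here, the exchange on the amide-type nitrogen gives a 4.5-fold lower number from compound 3 to compound 4 (0.65 log units; beyond the scatter), the first step in this set that isolates a change in one place and shows that this substituent alone can move the number beyond the scatter. The change is not one of hydrogen-bond donors, hydrogen-bond acceptors or net charge, as both groups have none; what differs is a six-membered non-aromatic ring of carbon only giving way to a six-membered aromatic ring of carbon only, together with added bromine and methyl and a higher heavy-atom count. No measurement bears on why the number falls, so the step stands here as an observation without a cause.

The exchange alters the ring and adds both substituents at once, so the compounds shown do not say which of these changes accounts for the step; a plain phenyl group, or a phenyl carrying only the bromine or only the methyl, would separate them. They also leave open how the number responds to an amine or a carboxylic acid on this aromatic ring.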